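The compounds below may be only part of what the source reports. "The series", "measured", "known", "first", "only" and "open" are said of these compounds alone.

- Compound 1 `COc1ccc(/C=C(\C(=O)c2ccc(Br)cc2)S(=O)(=O)c2ccc(Br)cc2)cc1`: 25000 nM
- Compound 2 `O=C(/C(=C\c1ccc(Br)cc1)S(=O)(=O)c1ccc(Br)cc1)c1ccc(Br)cc1`: 10000 nM

Among the compounds with values here, in a functional assay on DU-145 cells (Homo sapiens) for inhibition, read by trypan blue exclusion, with a stated time of 96 h (on this read-out higher numbers stand for weaker inhibition of growth and lower numbers for stronger inhibition of growth), compound 2 gives 10000 nM, the lower of the two numbers so far. Compound 3 `O=C(/C(=C\c1ccc(Br)cc1)S(=O)(=O)c1ccc(Br)cc1)c1ccccc1O` has 2-hydroxyphenyl in place of 4-bromophenyl on a carbonyl carbon. Within the data shown here, only one measured step offers guidance: a 2.5-fold lower number from compound 1 to compound 2 (0.40 log units; beyond the scatter). That modest step, where bromo replaced methoxy, involved a different group, so it bears only loosely on this change. Among the measured compounds shown here, a bromine also leaves here, so a small rise, no larger than that step, is expected in this assay. The expected change is a 1.5-fold higher number from compound 2 to compound 3 (0.18 log units; within the scatter). For compound 3, the estimate is 15000 nM, with an expected range of 4000 nM to 50000 nM.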

Compound 3, concentration for 50% growth inhibition: > 100000 nM
Compound 3: only a limit was reported; the forecaster's own chance of this, stated with the estimate: 10%; middle value at least 6.6-fold (0.82 log units) away from the limit.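

Replacing 4-bromophenyl with 2-hydroxyphenyl on the carbonyl carbon gives an at least 10-fold higher number from compound 2 to compound 3 (1.00 log units; beyond the scatter), so growth inhibition weakens clearly. Within the data shown here, this is the first look at that position, and it shows that the group on the carbonyl carbon matters. Compound 3 is reported only as a limit, > 100000 nM, so the full size of the step cannot be read: the limit of > 100000 nM in this assay, at which 1 of the 3 values shown sits.

The compounds shown leave open whether losing the bromo or gaining the hydroxyl matters more, as both changed together. Also open, as far as these compounds go, is how a phenyl carrying an amine or a carboxylic acid would behave there.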